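Removing a Methyl from a Methoxy Group on the Core

The source may report more compounds than this note shows. Statements on the series, on what has been measured and on what is new or still open speak of the compounds shown alone.

Of the compounds shown here, two sharing one core have been measured so far. Compound 1 `COc1cc2oc(-c3cccc(NC(=O)c4ccc(Br)cc4)c3)cc(=O)c2c(OC)c1OC` carries a ((4-bromophenyl)carbonyl)amino group on its pendant aromatic ring, and in a functional assay on SN12C cells (Homo sapiens) for inhibition, read by sulforhodamine B assay, tested at 10 uM (a higher number here means more inhibition at the concentration tested (going by the name of the read-out), a lower number less inhibition), compound 1 gives 63.6%. Compound 2 `COc1cc2oc(-c3cccc(C(=O)Nc4ccc(Cl)cc4)c3)cc(=O)c2c(OC)c1OC` carries a (4-chlorophenyl)carbamoyl group in its place, and in this assay compound 2 gives 61.4%. Within the data shown here, the only measured step, a number 2.2 percentage points lower from compound 1 to compound 2 (within the scatter), lies within the scatter, so the two numbers cannot be told apart; compound 2 simply stands alongside compound 1.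

Compound 3 `COc1cc2oc(-c3cccc(C(=O)Nc4ccc(Cl)cc4)c3)cc(=O)c2c(O)c1OC` differs from compound 2 at a different site on the core: hydrogen in place of methyl on an oxygen on an aromatic ring. Among the measured compounds shown here, no measured step touches this kind of change, since the one step known concerns the pendant amide and its halogen, not the methoxy groups on the core. There is therefore no basis in the data for expecting a shift in either direction beyond the scatter, and the estimate must be wide. Compound 3 is expected to give about 55% in this assay, within a range from 25% to 80%, which means an expected step of a number 6.4 percentage points lower from compound 2 to compound 3 (within the scatter).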

Compound 3, a percentage reported as inhibition, at one concentration (the size of the read-out at that concentration, not a potency): 53%
Compound 3: middle estimate off by 2 percentage points, on the high side, within the range that was stated.
By their numbers in this assay, from the lowest: compounds 3, 2 and 1 (each within the scatter of the next, the first and the last beyond it).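

Methoxy to hydroxy is the first change on the core itself that can be read, and in this assay it gives a number 8.4 percentage points lower from compound 2 to compound 3 (within the scatter). At this single tested concentration, then, compound 3, with its free hydroxy on the aromatic ring, cannot be told apart from compound 2, so the methyl on this oxygen is not shown to matter for the inhibition read here. The finding rests on this one pair, which carries the (4-chlorophenyl)carbamoyl group, and no measurement at hand explains why the methyl can go without a step beyond the scatter.

As far as these compounds go, it remains open whether an ethoxy group or a longer chain on this oxygen, or an amine in place of the hydroxy, would give a step beyond the scatter, and whether the same change at the other methoxy groups on the core would leave the number level. Also open, from the compounds shown here alone, is whether methoxy to hydroxy would read the same way on compound 1, which carries the ((4-bromophenyl)carbonyl)amino group instead.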